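Amide-side ester variations on a bisindolylmaleimide series

The source may hold more compounds than are shown below. What is called first, only, known or untested is meant among the compounds shown, and "the series" means these compounds.

Measured compounds, each in a functional assay on A2780 cells (Homo sapiens) for cytotoxicity, read by MTT assay, with a stated time of 24 h; a higher number here means a weaker inhibitor, a lower number a stronger inhibitor:
Compound 1, `COC(=O)[C@@H](C)NC(=O)Cn1cc(C2=C(c3c[nH]c4ccccc34)C(=O)N(C)C2=O)c2ccccc21`, gives 15800 nM.
Compound 2, `COC(=O)CCNC(=O)Cn1cc(C2=C(c3c[nH]c4ccccc34)C(=O)N(C)C2=O)c2ccccc21`, gives 44500 nM.
Compound 3, `COC(=O)CC[C@@H](NC(=O)Cn1cc(C2=C(c3c[nH]c4ccccc34)C(=O)N(C)C2=O)c2ccccc21)C(=O)OC`, gives 32300 nM.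

Compound 2 holds the highest number of the three in this assay, though its gap to compound 3 is within the scatter a 1.4-fold lower number from compound 2 to compound 3 (0.14 log units; within the scatter); only compound 1 stands clearly apart, the step of a 2.8-fold higher number from compound 1 to compound 2 (0.45 log units; beyond the scatter) lying beyond the scatter.

Compound 4, `COC(=O)[C@@H](CC(C)C)NC(=O)Cn1cc(C2=C(c3c[nH]c4ccccc34)C(=O)N(C)C2=O)c2ccccc21`, differs from compound 2 in one place: 1-(methoxycarbonyl)-3-methylbutyl in place of 2-(methoxycarbonyl)ethyl on an amide-type nitrogen. The change restores the arrangement seen in compound 1, where the methoxycarbonyl sits on the carbon bonded to the amide-type nitrogen, and adds a branched chain on that carbon. The step of a 2.8-fold higher number from compound 1 to compound 2 (0.45 log units; beyond the scatter) shows that moving the methoxycarbonyl one carbon away from the amide-type nitrogen raised the number modestly; the step of a 2.0-fold higher number from compound 1 to compound 3 (0.31 log units; beyond the scatter) shows that adding a (methoxycarbonyl)methyl on that same carbon also raised it modestly. Within the data shown here, no measured pair covers adding an alkyl branch alone.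

The expected step of a 2.5-fold lower number from compound 2 to compound 4 (0.39 log units; beyond the scatter) is therefore a modest drop in this assay, largely reversing the step from compound 1 to compound 2. Compound 4 is estimated at 18000 nM, with a range from 7000 nM to 45000 nM.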

Compound 4, half-maximal inhibitory concentration: 38500 nM
For compound 4 the middle estimate is 2.1-fold (0.33 log units) below the measured one, and the stated range covers the measured number.
By their numbers in this assay, from the lowest: compound 1; then compounds 3, 4 and 2 (each within the scatter of the next).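

Extending the chain from compound 1 costs activity whichever group is added: isopropyl in place of hydrogen on the saturated chain carbon, two bonds along the chain from the amide-type nitrogen and the carbonyl carbon, gives a 2.4-fold higher number from compound 1 to compound 4 (0.39 log units; beyond the scatter) in this assay, close to the earlier (methoxycarbonyl)methyl result. Replacing 2-(methoxycarbonyl)ethyl with 1-(methoxycarbonyl)-3-methylbutyl gives a 1.2-fold lower number from compound 2 to compound 4 (0.06 log units; within the scatter), and isopropyl in place of (methoxycarbonyl)methyl gives a 1.2-fold higher number from compound 3 to compound 4 (0.08 log units; within the scatter), so these three compounds form one group that this assay does not separate, with only compound 1 apart from it. Nothing measured here explains this.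

Still open, from the compounds shown here alone, is whether a carboxylic acid in place of the methoxycarbonyl would shift the number. Going by these compounds, the effect of an amine or a longer chain on that carbon is equally open.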